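Adding methoxy to the phenyl of compound 2

The source may report more compounds than this note shows. Statements on the series, on what has been measured and on what is new or still open speak of the compounds shown alone.

Compound 1 `Nc1nc(N)c2cc(CSC(=S)N3CCN(C4CCCCC4)CC3)ccc2n1`: 4050 nM
Compound 2 `Nc1nc(N)c2cc(CSC(=S)N3CCN(c4ccccc4)CC3)ccc2n1`: 2760 nM

In a functional assay on HT-29 cells (Homo sapiens) for antiproliferative activity, read by MTT assay, with a stated time of 72 h (on this read-out lower numbers stand for stronger inhibition and higher numbers for weaker inhibition), compound 2 gives 2760 nM, which lies within the scatter of compound 1. Compound 3 `COc1ccc(N2CCN(C(=S)SCc3ccc4nc(N)nc(N)c4c3)CC2)cc1` differs from compound 2 by methoxy in place of hydrogen on an aromatic carbon, so phenyl becomes 4-methoxyphenyl. Going by the values given here, only one measured step touches this substituent: a 1.5-fold lower number from compound 1 to compound 2 (0.17 log units; within the scatter), with phenyl in place of cyclohexyl on an amine nitrogen in a ring. No methoxy change has been measured, so this evidence is thin, and no step beyond the scatter is expected in this assay. The expected step is a 1.1-fold lower number from compound 2 to compound 3 (0.03 log units; within the scatter). Compound 3 is estimated at 2600 nM, with an expected range of 1100 nM to 6000 nM.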

Compound 3, half-maximal inhibitory concentration: 1770 nM
For compound 3 the middle estimate is 1.5-fold (0.17 log units) above the measured one; low and high end bracket the measured number.
By their numbers in this assay, from the lowest: compounds 3, 2 and 1 (each within the scatter of the next, the first and the last beyond it).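

In this assay the step for adding methoxy to the phenyl is a 1.6-fold lower number from compound 2 to compound 3 (0.19 log units; within the scatter), so this position takes the added group with no clear loss of activity. The larger swap, 4-methoxyphenyl for cyclohexyl, gives a 2.3-fold lower number from compound 1 to compound 3 (0.36 log units; beyond the scatter), the only step shown that lies beyond the scatter, and a modest one. Nothing in hand explains either number.

Open, on these data alone, is whether a smaller or differently built group, such as chlorine, hydroxyl or an amine, would read the same in this place. One methoxy compound cannot show a trend at this position.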